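From methoxy to chloro in the series

A few compounds are considered here, and "the series" means these few. Any claim that something is new, unique, unknown or untested is made for them only; others in the source may bear on it.

In a functional assay on MDA-MB-435 cells (Homo sapiens) for antiproliferative activity, read by CellTiter-Glo, with a stated time of 96 h (on this read-out lower numbers stand for stronger inhibition and higher numbers for weaker inhibition), compound 1 (`COc1ccc(-c2nsc3c2NC(=O)CC3c2ccc(F)cc2)cc1`) gives 1820 nM and compound 2 (`COc1ccc(-c2nsc3c2NC(=O)CC3c2ccsc2)cc1`) gives 80.7 nM, the lower of the two numbers. Within the data shown here, the only measured step, a 23-fold lower number from compound 1 to compound 2 (1.35 log units; beyond the scatter), is large and lies beyond the scatter, but it concerns thiophen-3-yl in place of 4-fluorophenyl on a saturated ring carbon. Compound 3 (`O=C1CC(c2ccsc2)c2snc(-c3ccc(Cl)cc3)c2N1`) keeps thiophen-3-yl and has chloro in place of methoxy on an aromatic carbon, para to a large group: chloro in place of methoxy on an aromatic carbon. Among the measured compounds shown here, no measured step covers this place, so neither size nor direction is established by the data. A moderate move towards a higher number in this assay is tentatively expected, and the range stays wide. The expected change is a 2.2-fold higher number from compound 2 to compound 3 (0.35 log units; beyond the scatter). For compound 3 the estimated value is 180 nM, with an expected range from 45 nM to 750 nM.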

Compound 3, half-maximal inhibitory concentration: 628 nM
For compound 3 the middle estimate is 3.5-fold (0.54 log units) below the measured one, within the range that was stated.
By their numbers in this assay, from the lowest: compound 2; then compound 3; then compound 1.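

In this assay, the aromatic carbon carrying methoxy now has its first measured step, with thiophen-3-yl held constant (a 7.8-fold higher number from compound 2 to compound 3 (0.89 log units; beyond the scatter)). This position therefore responds to the change, and of this pair, methoxy gives the lower number. The step is classed as modest, whereas the change on the saturated ring carbon (a 23-fold lower number from compound 1 to compound 2 (1.35 log units; beyond the scatter)) is classed as large, so both places affect the read-out, though with steps of different printed size. Nothing available explains why chloro gives the higher number here.

From the compounds shown here alone, whether the same change would give a similar step with 4-fluorophenyl on the saturated ring carbon remains open. Also open, going by these compounds, is how an amine or an ethoxy group at this aromatic carbon would compare with methoxy and chloro.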